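Replacing a Ring Methyl with 4-Bromophenyl: Expected Shift

This account rests on a few compounds, and the source may have more. Where it says the series, first, only, none or still open, it means among the compounds named here.

Compound 1, `CCCn1c(=O)[nH]c2nc(-c3ccc(S(=O)(=O)N4CCN(C)CC4)cc3)[nH]c2c1=O`, gives 7% in an assay on CHO cells for displacement of a labelled ligand from adenosine receptor A3 (Homo sapiens), read by scintillation counting, with a stated time of 45 min, tested at 1 uM, in the presence of a further agent that is not named here (a higher number here means more inhibition at the concentration tested (going by the name of the read-out), a lower number less inhibition), the lowest of the two numbers measured here. Its nearest neighbour, compound 2, `CCCn1c(=O)[nH]c2nc(-c3ccc(S(=O)(=O)N4CCN(Cc5ccc(Br)cc5)CC4)cc3)[nH]c2c1=O`, gives 28% in this assay, and the step of a number 21 percentage points higher from compound 1 to compound 2 (beyond the scatter) lies beyond the scatter. The unmeasured compound 3, `CCCn1c(=O)[nH]c2nc(-c3ccc(S(=O)(=O)N4CCN(c5ccc(Br)cc5)CC4)cc3)[nH]c2c1=O`, differs from compound 1 in one place: 4-bromophenyl in place of methyl on an amine nitrogen in a ring.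

Within the data shown here, only one measured step bears on this change. In the step from compound 1 to compound 2 the same 4-bromophenyl entered, there on a saturated chain carbon bound to the amine nitrogen in a ring rather than on that nitrogen itself, and it produced a number 21 percentage points higher from compound 1 to compound 2 (beyond the scatter). Among the measured compounds shown here, no measured step covers the group sitting directly on the ring nitrogen. Because a number 21 percentage points higher from compound 1 to compound 2 (beyond the scatter) was modest, a rise of similar size is expected for compound 3, with wider uncertainty given the different point of attachment. Compound 3 is thus expected to show a number 17 percentage points higher from compound 1 to compound 3 (beyond the scatter). For compound 3 the estimate in this assay is 24%, with a range from 5% to 48%.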

Compound 3, a percentage reported as inhibition, at one concentration (the size of the read-out at that concentration, not a potency): 29%
Beside the measured number, compound 3's estimate is 5 percentage points below it, and the stated range covers the measured number.
By their numbers in this assay, from the lowest: compound 1; then compounds 2 and 3 (each within the scatter of the next).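

With the 4-bromophenyl set directly on the amine nitrogen in a ring, this assay gives a number 22 percentage points higher from compound 1 to compound 3 (beyond the scatter), so the rise over the methyl compound does not need the saturated chain carbon that carries the same ring in compound 2. Exchanging 4-bromobenzyl for 4-bromophenyl on that nitrogen gives a number 1 percentage points higher from compound 2 to compound 3 (within the scatter), and at this position the two groups cannot be told apart in this read-out, although the two attachments had until now been linked only by an estimate. Nothing available here bears on why the two groups read alike.

From the compounds shown here alone, what a plain phenyl, a 4-chlorophenyl or a longer chain such as 2-phenylethyl would give on this nitrogen remains open, and with it whether the bromine has any part in the rise over the methyl compound. Going by these compounds, all of these numbers also come from a single concentration, so it remains open how the effects of compound 1, compound 2 and compound 3 would compare at other concentrations, or whether the similar read-outs of compound 2 and compound 3 would hold across a range of concentrations.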